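Para-substituent variation on a triazole-pyridine anticonvulsant series

A few compounds are considered here, and "the series" means these few. Any claim that something is new, unique, unknown or untested is made for them only; others in the source may bear on it.

Measured so far in a functional assay on the whole organism with Mus musculus as the target, in the maximal electroshock model; on this read-out higher numbers stand for an effect only at larger amounts of compound and lower numbers for an effect already at smaller amounts:
Compound 1, `Clc1ccc(-n2nncc2-c2cccnc2)cc1`, gives 65.8 mg/kg.
Compound 2, `c1ccc(-n2nncc2-c2cccnc2)cc1`, gives 76.4 mg/kg.
Compound 3, `FC(F)(F)c1ccc(-n2nncc2-c2cccnc2)cc1`, gives 92.3 mg/kg.

Compound 3 has the highest of the three numbers, but its steps to the other two compounds, a 1.4-fold higher number from compound 1 to compound 3 (0.15 log units; within the scatter) and a 1.2-fold higher number from compound 2 to compound 3 (0.08 log units; within the scatter), both lie within the scatter, so the three compounds cannot be told apart on these data. Compound 4, `Fc1ccc(-n2nncc2-c2cccnc2)cc1`, has not yet been measured. It differs from compound 3 by fluoro in place of trifluoromethyl on an aromatic carbon. For the measured compounds named here, the steps that bear on this change are the two that alter the same position of the shared core: a 1.2-fold higher number from compound 2 to compound 3 (0.08 log units; within the scatter) and a 1.4-fold higher number from compound 1 to compound 3 (0.15 log units; within the scatter), along with a 1.2-fold higher number from compound 1 to compound 2 (0.06 log units; within the scatter), none of which left the scatter. On that basis a step of a 1.2-fold lower number from compound 3 to compound 4 (0.09 log units; within the scatter) is expected, that is, no change beyond the scatter in this assay. Compound 4 is therefore estimated to give 75 mg/kg, with a range from 45 mg/kg to 125 mg/kg.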

Compound 4, dose for half-maximal effect: 74.6 mg/kg
For compound 4 the middle estimate is 1.0-fold (0.00 log units) above the measured one; the measured number falls inside the stated range.
By their numbers in this assay, from the lowest: compounds 1, 4, 2 and 3 (each within the scatter of the next).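

With fluoro on an aromatic carbon para to a large group, the series now holds four substituents at this place, and in this assay every step to the new compound lies within the scatter (a 1.2-fold lower number from compound 3 to compound 4 (0.09 log units; within the scatter); a 1.0-fold lower number from compound 2 to compound 4 (0.01 log units; within the scatter); a 1.1-fold higher number from compound 1 to compound 4 (0.05 log units; within the scatter)). Exchanging trifluoromethyl, with 4 heavy atoms, for fluoro, with 1 heavy atom, therefore leaves the read-out unresolved, and hydrogen, fluoro, chloro and trifluoromethyl cannot be told apart at this place. Nothing available explains why these four compounds cannot be separated.

Going by these compounds, it remains open whether an amine, a carboxylic acid or a methoxy group at this place would give a step beyond the scatter. The data also leave open whether any of these groups would behave the same way elsewhere on the shared core.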